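Nitro to Methoxy on Two Related Cores

The compounds below may be only part of what the source reports. "The series", "measured", "known", "first", "only" and "open" are said of these compounds alone.

Compound 1, `CCCc1n[nH]c2c(=O)n(NC(=O)c3ccccc3)c(-c3cccc([N+](=O)[O-])c3)nc12`: 28.8%
Compound 2, `CCCc1n[nH]c2c(=O)n(NC(=O)c3ccccc3)c(-c3cccc(OC)c3)nc12`: 9.96%
Compound 3, `O=C(Nn1c(-c2cccc([N+](=O)[O-])c2)nc2c(-c3ccc(Cl)cc3)n[nH]c2c1=O)c1ccccc1`: 86.8%

All three were tested in a functional assay on SK-OV-3 cells (Homo sapiens) for cytotoxicity, read by sulforhodamine B assay, with a stated time of 2 days, tested at 100 uM; on this read-out lower numbers stand for less inhibition and higher numbers for more inhibition at the one concentration tested (going by the name of the read-out). Compound 2 differs from compound 1 by methoxy in place of nitro on an aromatic carbon, and this gave a number 18.8 percentage points lower from compound 1 to compound 2 (beyond the scatter). Compound 3 stands on a different core, the difference being (4-chlorophenyl in place of propyl on an aromatic carbon), and this gave a number 58 percentage points higher from compound 1 to compound 3 (beyond the scatter); compound 3 has the highest number of the three. Compound 4, `COc1cccc(-c2nc3c(-c4ccc(Cl)cc4)n[nH]c3c(=O)n2NC(=O)c2ccccc2)c1`, has not been measured. It differs from compound 3 by methoxy in place of nitro on an aromatic carbon. The place of the change is the same as in the pair of compound 1 and compound 2, so the same change is made on the core of compound 3. The step is expected to be a number 18.8 percentage points lower from compound 3 to compound 4 (beyond the scatter) in this assay, resting on a number 18.8 percentage points lower from compound 1 to compound 2 (beyond the scatter). Compound 4 is estimated at 68%, from 45% to 88%, because compound 3 gives 86.8%.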

Compound 4, a percentage reported as inhibition, at one concentration (the size of the read-out at that concentration, not a potency): 81.7%
Estimate against measurement, compound 4: 13.7 percentage points below; measured number inside the range.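

Methoxy in place of nitro on the core of compound 3 gave a number 5.1 percentage points lower from compound 3 to compound 4 (within the scatter) in this assay, yet this step does not differ meaningfully from the one on the core of compound 1: the same change on two cores in this assay, a number 18.8 percentage points lower (beyond the scatter) from compound 1 to compound 2 and a number 5.1 percentage points lower (within the scatter) from compound 3 to compound 4, 13.7 percentage points apart, within the scatter of two such steps The 4-chlorophenyl for propyl change also carried across, with methoxy in place of nitro, giving a number 71.7 percentage points higher from compound 2 to compound 4 (beyond the scatter), in agreement with the earlier step: the same change on two cores in this assay, a number 58 percentage points higher (beyond the scatter) from compound 1 to compound 3 and a number 71.7 percentage points higher (beyond the scatter) from compound 2 to compound 4, 13.7 percentage points apart, within the scatter of two such steps These four compounds form a single square with one pair per core, so they cannot show whether the nitro to methoxy step truly shrinks on the core of compound 3, or how it behaves on any further core.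

The compounds shown leave open how an amine or a carboxylic acid would read in place of nitro. They also leave open how a longer chain would compare with propyl and 4-chlorophenyl.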